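Growing the Ring by One Carbon: Cyclopentyl to Cyclohexyl

A few compounds are considered here, and "the series" means these few. Any claim that something is new, unique, unknown or untested is made for them only; others in the source may bear on it.

Of the compounds shown here, two have been measured so far in an in vitro ADME assay on microsomes from liver (Homo sapiens) for metabolic stability; on this read-out higher numbers stand for a longer-lived compound and lower numbers for a shorter-lived compound. Compound 1 `CC(C)CCn1nc(-c2cccs2)c(O)c(C2=NS(=O)(=O)c3cc(OCC(N)=O)ccc3N2)c1=O` gives 0.383 h. Within the data shown here, compound 2 `NC(=O)COc1ccc2c(c1)S(=O)(=O)N=C(c1c(O)c(-c3cccs3)nn(CC3CCCC3)c1=O)N2` gives 0.433 h in this assay, and it stands level with compound 1, since the one step known, a 1.1-fold higher number from compound 1 to compound 2 (0.05 log units; within the scatter), lies within the scatter. Compound 3 `NC(=O)COc1ccc2c(c1)S(=O)(=O)N=C(c1c(O)c(-c3cccs3)nn(CC3CCCCC3)c1=O)N2` carries cyclohexyl in place of cyclopentyl on a saturated chain carbon bound to an aromatic nitrogen. This is a change of the same kind as the earlier one, so no shift beyond the scatter is expected in this assay, because a 1.1-fold higher number from compound 1 to compound 2 (0.05 log units; within the scatter) was itself so small. Compound 3 is therefore estimated at 0.45 h, with a range from 0.25 h to 0.8 h. For compound 3 this expectation corresponds to a step of a 1.0-fold higher number from compound 2 to compound 3 (0.02 log units; within the scatter).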

Compound 3, half-life: > 1 h
Compound 3: a limit, no number (the forecaster's own chance of this, stated with the estimate: 5%); at least 2.2-fold (0.34 log units) between middle value and limit.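

In this assay this position turns out not to be indifferent: cyclohexyl in place of cyclopentyl gives an at least 2.3-fold higher number from compound 2 to compound 3 (0.36 log units; beyond the scatter) and cyclohexyl in place of isobutyl gives an at least 2.6-fold higher number from compound 1 to compound 3 (0.41 log units; beyond the scatter) while the earlier swap stayed within the scatter. Among the three groups shown, only the cyclohexyl ring separates its compound from the others. Compound 3 gives a limit and not a number, so the full size of both steps stays unknown: the limit of > 1 h in this assay, at which 1 of the 3 values shown sits.

Open, as far as these compounds go, is whether a cycloheptyl ring would carry the rise further, and whether a longer chain between ring and aromatic nitrogen would keep it.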